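Fluoro for chloro on the pyridine of compound 1

This account rests on a few compounds, and the source may have more. Where it says the series, first, only, none or still open, it means among the compounds named here.

Within the data shown here, compound 1 `Nc1ccccc1NC(=O)c1ccc(NC(=O)NCc2ccc(Cl)nc2)cc1` carries the only number reported for the series in a functional assay on HCT-116 cells (Homo sapiens) for cytotoxicity, read by MTT assay, with a stated time of 72 h; a lower number here means a stronger inhibitor, a higher number a weaker inhibitor. In this assay compound 1 gives 5200 nM. Compound 2 `Nc1ccccc1NC(=O)c1ccc(Cn2cc(-c3ccc(NC(=O)NCc4cccnc4)cc3)nn2)cc1` gives in this assay only > 100000 nM, which is a limit of the assay and not a number; this is the limit of > 100000 nM in this assay, at which 1 of the 2 values shown sits. Among the measured compounds shown here, no two measured compounds differ in a single place, so no measured step sets a scale for the change now under study. Compound 3 `Nc1ccccc1NC(=O)c1ccc(NC(=O)NCc2ccc(F)nc2)cc1` is to be measured in this assay. It differs from compound 1 in one place (fluoro in place of chloro on an aromatic carbon). The expectation rests on compound 1 alone, since nothing measured here speaks to such an exchange. The expected step is small, a 1.3-fold higher number from compound 1 to compound 3 (0.10 log units; within the scatter), not beyond the usual scatter or at most a slight weakening. Compound 3 is therefore estimated at 6500 nM in this assay, with a range from 2500 nM to 17000 nM.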

Compound 3, half-maximal inhibitory concentration: 14000 nM
Compound 3: middle estimate off by 2.2-fold (0.33 log units), on the low side; low and high end bracket the measured number.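

In this assay the exchange of 6-chloropyridin-3-yl for 6-fluoropyridin-3-yl gives a 2.7-fold higher number from compound 1 to compound 3 (0.43 log units; beyond the scatter), so the number at this position depends on which halogen it carries. Among these compounds, this is the first measured single-place step, and it sets a scale that compound 1 alone could not: one heavy atom is exchanged, the counts of hydrogen-bond donors and acceptors stay the same, and the step still lies beyond the scatter. Chloro holds the lower number in this one pair, and nothing measured here accounts for the difference.

On these data alone, one pair fixes no order among substituents, so it remains open how bromo, methyl, methoxy or a bare hydrogen would read at the same place. Also open, as far as these compounds go, is whether a step of this size would hold on another core.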